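The source may hold more compounds than are shown below. What is called first, only, known or untested is meant among the compounds shown, and "the series" means these compounds.

The measured compounds:
compound 1, `CN(C)CCNc1ccnc2cc(OCc3ccc(F)cc3)ccc12`, which in a functional assay on BGC-823 cells (Homo sapiens) for cytotoxicity, read by MTT assay, with a stated time of 48 h (on this read-out higher numbers stand for weaker inhibition and lower numbers for stronger inhibition), gives 890 nM;
compound 2, `CCOc1ccc2c(NCCN(C)C)ccnc2c1`, which in this assay gives 2520 nM.

Compound 2 thus holds the higher of the two numbers. Its nearest neighbour is compound 1, and the step of a 2.8-fold higher number from compound 1 to compound 2 (0.45 log units; beyond the scatter) separates them, the change being methyl in place of 4-fluorophenyl on a saturated chain carbon bound to an oxygen on an aromatic ring.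

Compound 3, `CCCCCCOc1ccc2c(NCCN(C)C)ccnc2c1`, has not yet been measured. It differs from compound 2 by butyl in place of hydrogen on a saturated chain carbon, two bonds along the chain from an oxygen on an aromatic ring, so the ethoxy of compound 2 becomes a hexyloxy. Only one measured step bears on this, the one from compound 1 to compound 2 given above, and it concerned a different kind of group at this oxygen; it shows that the ethoxy of compound 2 gave the higher number, and the lengthened chain is the sole guide. On that basis compound 3 is expected to show a modest step downward, a 1.7-fold lower number from compound 2 to compound 3 (0.23 log units; within the scatter). Compound 3 is therefore estimated at 1500 nM in this assay, with a range from 500 nM to 4500 nM.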

Compound 3, half-maximal inhibitory concentration: 1090 nM
Compound 3: middle estimate off by 1.4-fold (0.14 log units), on the high side; measured number inside the range.
By their numbers in this assay, from the lowest: compounds 1 and 3 (each within the scatter of the next); then compound 2.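

In this assay, lengthening the ethoxy of compound 2 to the hexyloxy of compound 3 gives a 2.3-fold lower number from compound 2 to compound 3 (0.36 log units; beyond the scatter), which beyond the scatter shows that this position responds to a change in a plain saturated chain alone, whereas the earlier step had exchanged methyl for 4-fluorophenyl. The second new step, a 1.2-fold higher number from compound 1 to compound 3 (0.09 log units; within the scatter), lies within the scatter, so compound 1 and compound 3 cannot be told apart in this assay, and among these compounds a terminal 4-fluorophenyl is not needed to reach the level of compound 1, since a pentyl in its place serves as well. Nothing available gives a reason for either step.

With only the ethoxy and hexyloxy chains to compare, the compounds shown cannot say whether the number changes steadily with chain length or whether an intermediate butoxy or a longer decyloxy would continue, level off or reverse the step. They also leave open how the position would respond to a chain ending in a hydroxyl, an amine or a carboxylic acid.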